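Replacing the acid of compound 3 with an anilide

The source may hold more compounds than are shown below. What is called first, only, known or untested is meant among the compounds shown, and "the series" means these compounds.

Four compounds share one core. Compound 1, `C=CC1=C(C(=O)NC2CCCCC2)C(c2ccc(OC)c(OC)c2)OC1`, carries a cyclohexyl amide, and in a functional assay on SW480 cells (Homo sapiens) for cytotoxicity, read by MTT assay, with a stated time of 24 h (a higher number here means a weaker inhibitor, a lower number a stronger inhibitor), compound 1 gives 19100 nM. Compound 2, `C=CC1=C(C(=O)NCc2ccc(C)cc2)C(c2ccc(OC)c(OC)c2)OC1`, carries a 4-methylbenzyl amide. In this assay compound 2 reaches only a limit, > 100000 nM. Compound 3, `C=CC1=C(C(=O)O)C(c2ccc(OC)c(OC)c2)OC1`, is the free carboxylic acid. In this assay compound 3 also reaches only a limit, > 100000 nM. Compound 3 therefore stands at the limit of > 100000 nM in this assay, at which 2 of the 3 values shown sit, and the step of an at least 5.2-fold higher number from compound 1 to compound 3 (0.71 log units; beyond the scatter) shows that the acid is weaker than the cyclohexyl amide, while the step that the two limits leave unreadable from compound 2 to compound 3 cannot be read. Compound 4, `C=CC1=C(C(=O)Nc2ccccc2)C(c2ccc(OC)c(OC)c2)OC1`, arises from compound 3 by anilino in place of hydroxy on a carbonyl carbon. The only readable amide, in compound 1, improved on the acid; the aromatic amide of compound 2 did not rise above the limit. For compound 4 a modest gain on compound 3 is therefore expected, an at least 2.0-fold lower number from compound 3 to compound 4 (0.30 log units; that floor lies within the scatter), and the estimate for compound 4 is 50000 nM, with a range from 12000 nM to 150000 nM.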

Compound 4, half-maximal inhibitory concentration: 45100 nM
Estimate against measurement, compound 4: 1.1-fold (0.04 log units) above, and the stated range covers the measured number.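

An amide on this carbonyl carbon need not carry cyclohexyl to improve on the acid: anilino in place of hydroxy gives an at least 2.2-fold lower number from compound 3 to compound 4 (0.34 log units; beyond the scatter). On the amide-type nitrogen, phenyl also separates from 4-methylbenzyl, with an at least 2.2-fold lower number from compound 2 to compound 4 (0.34 log units; beyond the scatter), yet it falls short of cyclohexyl, with a 2.4-fold higher number from compound 1 to compound 4 (0.37 log units; beyond the scatter). Compound 2 and compound 3 both remain at a limit of the assay, so the step between them cannot be read and neither can be ranked precisely: the limit of > 100000 nM in this assay, at which 2 of the 4 values shown sit.

Going by these compounds, whether cyclopentyl or an unsubstituted benzyl on the same nitrogen would come closer to compound 1 or to compound 4 stays open. So does whether a methoxy group or a chlorine on the phenyl ring of compound 4 would shift its number, and the compounds shown do not explain the order among the amides.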